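Swapping the chlorophenyl amide for an acetoxyacetamide

A few compounds are considered here, and "the series" means these few. Any claim that something is new, unique, unknown or untested is made for them only; others in the source may bear on it.

Compound 2 `C#CCNC1CCc2c(OCCc3cc(NC(=O)c4ccc(Cl)cc4)ccc3Cl)cccc21` stands at a limit in an assay on cells for inhibition of Amine oxidase [flavin-containing] B (Homo sapiens), read by fluorescence and Amplex Red, with stated times of 30 min and 15 min; a higher number here means a weaker inhibitor, a lower number a stronger inhibitor: it gives > 20000 nM, a limit of the assay and not a number. Compound 1 `C#CCNC1CCc2c(OCCc3cc(NC(=O)c4ccccc4)ccc3Cl)cccc21` likewise gives only a limit, > 20000 nM. The step that the two limits leave unreadable from compound 1 to compound 2 therefore cannot be read, since both values sit at the limit of > 20000 nM in this assay, at which 2 of the 2 values shown sit. Compound 3 `C#CCNC1CCc2c(OCCc3cc(NC(=O)COC(C)=O)ccc3Cl)cccc21` differs from compound 2 by acetoxymethyl in place of 4-chlorophenyl on a carbonyl carbon. Among the compounds with values here, no measured step bears readably on this change, so the expected step of a number no higher from compound 2 to compound 3 (the limit leaves the size open) carries no readable direction. The estimate for compound 3 is 20000 nM, ranging from 4000 nM to 100000 nM, with another limit expected as the most likely outcome.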

Compound 3, half-maximal inhibitory concentration: 480 nM
Estimate against measurement, compound 3: 42-fold (1.62 log units) above; measured number outside the range, below it.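

Acetoxymethyl in place of 4-chlorophenyl on a carbonyl carbon gives an at least 41-fold lower number from compound 2 to compound 3 (1.61 log units; beyond the scatter), and acetoxymethyl in place of phenyl gives an at least 41-fold lower number from compound 1 to compound 3 (1.61 log units; beyond the scatter). The group on this carbonyl carbon therefore decides whether a number can be read at all in this assay. Compound 1 and compound 2 could not show this, as each gives only a limit: the limit of > 20000 nM in this assay, at which 2 of the 3 values shown sit.

Whether the ester or the loss of the aromatic ring accounts for these steps stays open. A hydroxymethyl or a plain methyl group on this carbonyl carbon would tell the two apart.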